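Chloro to fluoro swap carried across two cores

This account rests on a few compounds, and the source may have more. Where it says the series, first, only, none or still open, it means among the compounds named here.

Measured in a functional assay on the whole organism (artery, strain albino) with Rattus norvegicus as the target, with a stated time of 300 min, at a dose of 10 mg/kg by the oral route; a lower number here means less inhibition, a higher number more inhibition at the dose given (going by the name of the read-out):
compound 1 `CC1=C(C(=O)Nc2ccc(F)cc2)C(c2ccc([N+](=O)[O-])cc2)N=C(SCc2ccc(Cl)cc2)N1`: 37.9%
compound 2 `CC1=C(C(=O)Nc2ccc(F)cc2)C(c2ccc([N+](=O)[O-])cc2)N=C(SCc2ccc(F)cc2)N1`: 30.3%
compound 3 `COc1ccc(C2N=C(SCc3ccc(Cl)cc3)NC(C)=C2C(=O)Nc2ccc(Br)cc2)cc1`: 37.9%

Compound 1 and compound 2 differ at a single point, (fluoro in place of chloro on an aromatic carbon), and the step in this assay is a number 7.6 percentage points lower from compound 1 to compound 2 (within the scatter). Compound 3 is built on a different core; how that core differs from the core of compound 1 is not broken down here. In this assay the numbers of compound 1, compound 2 and compound 3 all sit within the scatter of one another, so no order among them can be read.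

Compound 4 `COc1ccc(C2N=C(SCc3ccc(F)cc3)NC(C)=C2C(=O)Nc2ccc(Br)cc2)cc1` has not yet been measured. It differs from compound 3 by fluoro in place of chloro on an aromatic carbon, the same change as that between compound 1 and compound 2, at a place described in the same words. Among the compounds with values here, for compound 4 in this assay the step is expected to be small, estimated as a number 6.9 percentage points lower from compound 3 to compound 4 (within the scatter), because the only measured example of this change is a number 7.6 percentage points lower from compound 1 to compound 2 (within the scatter) and compound 3 starts from 37.9%. On that basis compound 4 is estimated at 31%, with a likely range from 18% to 44%.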

Compound 4, a percentage reported as inhibition, in the whole organism at one dose (the size of the read-out at that dose, not a potency): 26.2%
Compound 4: the middle estimate sits 4.8 percentage points above what was measured, within the range that was stated.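

In this assay, going from 4-chlorobenzyl to 4-fluorobenzyl on the core of compound 3 gives a number 11.7 percentage points lower from compound 3 to compound 4 (beyond the scatter). Set beside the same change on the core of compound 1, the step does not differ measurably between the two cores: the same change on two cores in this assay, a number 7.6 percentage points lower (within the scatter) from compound 1 to compound 2 and a number 11.7 percentage points lower (beyond the scatter) from compound 3 to compound 4, 4.1 percentage points apart, within the scatter of two such steps. Within the data shown here, the change can therefore be carried between these two cores with no detectable shift in step size, but this does not establish a real drop on both cores, as only the step on the core of compound 3 lies beyond the scatter, and two pairs say nothing about any further core.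

From the compounds shown here alone, only chloro and fluoro appear at this place, so it remains open how trifluoromethyl, an amine or a carboxylic acid there would read in this assay. Also open, going by these compounds, is whether a longer chain in place of the benzyl link would leave the step from chloro to fluoro as it stands.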